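A few compounds are considered here, and "the series" means these few. Any claim that something is new, unique, unknown or untested is made for them only; others in the source may bear on it.

Measured compounds:
Compound 1, `O=[N+]([O-])c1ccc(NC(=S)N2CCN(S(=O)(=O)c3sccc3-c3ccccc3Oc3ccc(O)c(O)c3)CC2)cc1`: in an ADME assay on HEK-293T cells (Homo sapiens) for cytotoxicity, read by CCK-8 assay, with a stated time of 48 h (a lower number here means a stronger inhibitor, a higher number a weaker inhibitor), compound 1 gives only a limit, > 20000 nM.
Compound 2, `O=[N+]([O-])c1ccc(NC(=S)NCCNS(=O)(=O)c2ccc(-c3ccccc3O[C@H]3CC[C@H](O)CC3)s2)cc1`: in this assay compound 2 gives 10500 nM.

Among the compounds with values here, compound 2 therefore stands as the only compound with a real number in this assay; the other value shown is the limit of > 20000 nM in this assay, at which 1 of the 2 values shown sits, a limit rather than a number, so no measured step between the two can be drawn. Compound 3, `O=[N+]([O-])c1ccc(NC(=S)NCCNS(=O)(=O)c2ccc(-c3ccccc3OCc3cccc(O)c3)s2)cc1`, has not yet been tested. It differs from compound 2 in one place: 3-hydroxybenzyl in place of 4-hydroxycyclohexyl on an oxygen on an aromatic ring. Within the data shown here, with no measured step of this kind to lean on, the expectation rests on compound 2 alone, and the step of a 1.1-fold higher number from compound 2 to compound 3 (0.06 log units; within the scatter) is estimated to stay within the usual scatter, with no clear direction. Compound 3 is thus expected to give about 12000 nM in this assay, somewhere between 4500 nM and 30000 nM.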

Compound 3, half-maximal inhibitory concentration: > 20000 nM
Compound 3: only a limit was reported; the forecaster's own chance of this, stated with the estimate: 35%; at least 1.6-fold (0.22 log units) between middle value and limit.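

Placing 3-hydroxybenzyl in place of 4-hydroxycyclohexyl on an oxygen on an aromatic ring gives, in this assay, an at least 1.9-fold higher number from compound 2 to compound 3 (0.27 log units; that floor lies within the scatter). Within the data shown here, this is the first step that can be read at this position, and it is only a floor, so the real size of the change remains unknown; what it does show is that exchanging the non-aromatic ring for an aromatic one, with the same count of hydrogen-bond donors and acceptors, brings no lower number. Compound 2 remains the only compound with a real number, and the limit now accounts for most of the values: the limit of > 20000 nM in this assay, at which 2 of the 3 values shown sit.

The compounds shown leave open how a plain benzyl group without the hydroxyl, or an amine on the cyclohexyl ring in place of the hydroxyl, would read at this position. They also leave open how far the real value of compound 3 lies from its limit.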